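Cyclopropyl to methoxymethyl on the amide carbonyl

The source may report more compounds than this note shows. Statements on the series, on what has been measured and on what is new or still open speak of the compounds shown alone.

Of the compounds shown here, three on one shared core have so far been measured in an assay on isolated protein for binding affinity to melatonin receptor type 1B (Homo sapiens); a higher number here means a weaker inhibitor, a lower number a stronger inhibitor. Compound 1 `CCCC(=O)Nc1ccc(Oc2ccc(OC)cc2)cc1` gives only a limit of the assay, > 400 nM, the limit described in the limit of > 400 nM in this assay, at which 1 of the 3 values shown sits. Compound 2 `COc1cccc(Oc2ccc(NC(C)=O)cc2)c1` gives 4.1 nM in this assay. Compound 3 `COc1cccc(Oc2ccc(NC(=O)C3CC3)cc2)c1`, with cyclopropyl in place of methyl on the carbonyl carbon, gives 13 nM in this assay, and that exchange produced a 3.2-fold higher number from compound 2 to compound 3 (0.50 log units; beyond the scatter). Of the two numbers available, compound 3 therefore stands as the higher one, with compound 2 as its nearest neighbour, while compound 1 contributes only a limit.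

Compound 4 `COCC(=O)Nc1ccc(Oc2cccc(OC)c2)cc1` differs from compound 3 in a single place: methoxymethyl in place of cyclopropyl on a carbonyl carbon. Going by the values given here, the only measured step at that position is a 3.2-fold higher number from compound 2 to compound 3 (0.50 log units; beyond the scatter), a modest shift. Cyclopropyl and methoxymethyl each bring three heavy atoms to the carbonyl carbon, and the one prior exchange there moved the number only modestly, so a step of similar or smaller size is expected, its direction uncertain. Compound 4 is accordingly estimated to give 14 nM in this assay, with a range from 4 nM to 50 nM. That estimate amounts to an expected step of a 1.1-fold higher number from compound 3 to compound 4 (0.03 log units; within the scatter).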

Compound 4, inhibition constant: 5.9 nM
For compound 4 the middle estimate is 2.4-fold (0.38 log units) above the measured one; the measured number falls inside the stated range.
By their numbers in this assay, from the lowest: compounds 2 and 4 (each within the scatter of the next); then compound 3. At a limit, above all of these: compound 1.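

Exchanging cyclopropyl for methoxymethyl on the carbonyl carbon gives a 2.2-fold lower number from compound 3 to compound 4 (0.34 log units; beyond the scatter) in this assay, so this position responds to a change between two groups of equal heavy-atom count, one with a ring and one without. Set against the methyl group, the same side chain gives a 1.4-fold higher number from compound 2 to compound 4 (0.16 log units; within the scatter), which means that methoxy in place of hydrogen on the saturated chain carbon bound to the carbonyl carbon leaves no change that can be told from the scatter, and that of the three groups at this position only cyclopropyl stands apart from methyl. Nothing measured here offers an explanation for either step.

From the compounds shown here alone, whether an ethoxymethyl group, a longer chain or an amine such as dimethylaminomethyl on the same carbonyl carbon would keep the number in this range remains open. Compound 1 gives only a limit of the assay, > 400 nM, and it differs from the other compounds in more than one place, so it cannot settle that question.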